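The source may hold more compounds than are shown below. What is called first, only, known or untested is meant among the compounds shown, and "the series" means these compounds.

Measured compounds:
- compound 1, `C[C@H]1CC[C@@H]2[C@@H](OC(=O)[C@]23CC(c2ccc(Cl)cc2)=NO3)[C@]2(C)C(=O)C=C[C@@]12O`; in a physicochemical assay for lipophilicity (on this read-out lower numbers stand for lower lipophilicity and higher numbers for higher lipophilicity), compound 1 gives 2.09
- compound 2, `C[C@H]1CC[C@@H]2[C@@H](OC(=O)[C@]23CC(c2ccc(F)cc2)=NO3)[C@]2(C)C(=O)C=C[C@@]12O`; in this assay compound 2 gives 1.58
- compound 3, `C[C@H]1CC[C@@H]2[C@@H](OC(=O)[C@]23CC(c2ccc(Cl)cc2)N(c2ccccc2)O3)[C@]2(C)C(=O)C=C[C@@]12O`; in this assay compound 3 gives 3.87

Compounds 1 and 2 share a core and differ in one place: fluoro in place of chloro on an aromatic carbon. This change gives a number 0.51 log units lower from compound 1 to compound 2 (beyond the scatter), a step that lies beyond the scatter of the method.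

Compound 3 carries the highest of the three numbers in this assay; its nearest neighbour is compound 1, with compound 2 furthest away, and both gaps lie beyond the scatter. The difference between the core of compound 3 and the core of compound 1 is not broken down here.

Compound 4, `C[C@H]1CC[C@@H]2[C@@H](OC(=O)[C@]23CC(c2ccc(F)cc2)N(c2ccccc2)O3)[C@]2(C)C(=O)C=C[C@@]12O`, is not yet measured in this assay. It differs from compound 3 in one place: fluoro in place of chloro on an aromatic carbon. Going by the values given here, this is the same change as the one between compound 1 and compound 2, and it sits at the same place in both pairs. Among the compounds shown, the change occurs twice in all, once measured and once not.

The step expected from this change is a number 0.51 log units lower from compound 3 to compound 4 (beyond the scatter), which rests on the measured step of a number 0.51 log units lower from compound 1 to compound 2 (beyond the scatter) being carried over to the core of compound 3. The number for compound 4 in this assay is estimated at 3.36, with a likely range from 3 to 3.7.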

Compound 4, partition coefficient: 3.35
Compound 4: middle estimate off by 0.01 log units, on the high side, within the range that was stated.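

In this assay, the change from 4-chlorophenyl to 4-fluorophenyl gives a number 0.52 log units lower from compound 3 to compound 4 (beyond the scatter), and on the other core it gives a number 0.51 log units lower from compound 1 to compound 2 (beyond the scatter), so the two steps point the same way, are nearly the same size and each lie beyond the scatter. For this one change at this one place, the step therefore carried over from the core of compound 1 to the core of compound 3, even though compound 3 and compound 4 both sit much higher on this read-out than compound 1 and compound 2. This is one matched pair on each of two cores, so it does not establish a general rule for other cores, and nothing available explains why the steps agree.

The compounds shown leave open how an amine, a carboxylic acid or a longer chain such as butyl would read in place of the chloro on either core, and whether those steps would also match from one core to the other. They also leave open whether the agreement seen for fluoro and chloro would hold on a third core, or for bromo or methoxy at the same place.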